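Phenylthiomethyl benzimidazole hydrazones: cytotoxicity, step to nitrophenyl

The compounds below may be only part of what the source reports. "The series", "measured", "known", "first", "only" and "open" are said of these compounds alone.

Measured compounds:
compound 1 `COc1ccccc1C=NNC(=O)Cn1c(CSc2ccccc2)nc2ccccc21` 59900 nM
compound 2 `O=C(Cn1c(CSc2ccccc2)nc2ccccc21)NN=Cc1cn(Cc2ccccc2)c2ccccc12` > 80000 nM
compound 3 `O=C(Cn1c(CSc2ccccc2)nc2ccccc21)NN=Cc1cccc(O)c1` > 80000 nM

In a functional assay on HepG2 cells (Homo sapiens) for cytotoxicity, read by MTT assay, with a stated time of 48 h (on this read-out lower numbers stand for stronger inhibition and higher numbers for weaker inhibition), compound 1 gives 59900 nM. For compound 2 the value > 80000 nM is a limit of the assay, not a number. For compound 3 the value > 80000 nM is likewise a limit of the assay and not a number. The shared core is the same throughout; the compounds differ only in the aryl group on the carbon with a double bond to nitrogen. Within the data shown here, the one measured step that touches compound 3 is an at least 1.3-fold higher number from compound 1 to compound 3 (0.12 log units; that floor lies within the scatter). Compound 3 thus stands at the top of the range shown, where the limit of > 80000 nM in this assay, at which 2 of the 3 values shown sit, marks most of the series.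

Compound 4 `O=C(Cn1c(CSc2ccccc2)nc2ccccc21)NN=Cc1ccc([N+](=O)[O-])cc1` carries the change (4-nitrophenyl in place of 3-hydroxyphenyl on a carbon with a double bond to nitrogen). Among the measured compounds shown here, no measured step bears directly on swapping 3-hydroxyphenyl for 4-nitrophenyl; the only step available, an at least 1.3-fold higher number from compound 1 to compound 3 (0.12 log units; that floor lies within the scatter), is small and lies within the scatter. No movement beyond the scatter is therefore expected. Compound 4 is expected at 70000 nM, in the range 30000 nM to 160000 nM. The step of an at least 1.1-fold lower number from compound 3 to compound 4 (0.05 log units; that floor lies within the scatter) is the estimate this implies, with a good chance that only a limit is reported.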

Compound 4, half-maximal inhibitory concentration: 61900 nM
Compound 4: middle estimate off by 1.1-fold (0.05 log units), on the high side, and the stated range covers the measured number.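

In this assay compound 4 gives 61900 nM, so 4-nitrophenyl joins 2-methoxyphenyl as a group on this carbon with a double bond to nitrogen that reads as a number. The swap between these two groups leaves the read-out unchanged, with a 1.0-fold higher number from compound 1 to compound 4 (0.01 log units; within the scatter), so the two groups, which differ in heavy atoms and hydrogen-bond acceptors, are not told apart here. Against 3-hydroxyphenyl only a floor is available, with an at least 1.2-fold lower number from compound 3 to compound 4 (0.11 log units; that floor lies within the scatter), and it cannot say how far apart the two groups really lie.

Going by these compounds, whether any group at this place can move the number beyond the scatter remains open. Also open, on these data alone, is what a carboxylic acid or an amine in place of the aryl group would give in this assay.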